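This account rests on a few compounds, and the source may have more. Where it says the series, first, only, none or still open, it means among the compounds named here.

Measured compounds, with their values in an ADME assay on cells (Hepatocyte, Homo sapiens) for metabolic stability; on this read-out lower numbers stand for slow clearance and higher numbers for fast clearance:
- compound 1, `C[C@H](Oc1cc2cc(F)ccc2nc1N)c1cc2c(cnn2CC(=O)O)cc1-n1cccn1` — 21 uL/min
- compound 2, `C[C@H](Oc1cc2cc(C(N)=O)ccc2nc1N)c1cc(F)ccc1-n1cccn1` — 13 uL/min
- compound 3, `C[C@H](Oc1cc2cc(C(N)=O)ccc2nc1N)c1ncc(F)cc1-n1cccn1` — reported only as a limit of the assay, < 2 uL/min

Within the series, compound 2 and compound 1 differ by a gap that lies inside the usual scatter of this assay, so the two cannot be separated. For compound 3 only the limit of < 2 uL/min in this assay, at which 1 of the 3 values shown sits, is known, not a number.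

The unmeasured compound 4, `C[C@H](Oc1cc2cc(C(N)=O)ccc2nc1N)c1cc(F)c(F)cc1-n1cccn1`, is reached from compound 2 by the change (fluoro in place of hydrogen on an aromatic carbon). Among the compounds with values here, no measured pair carries the same change, so the size of the step has no precedent here. Given that the replacement adds a single heavy atom and no donor or acceptor, no step beyond the scatter of this assay is expected in either direction; if anything, a small drift toward slower clearance. Compound 4 is estimated to give 10 uL/min in this assay, within a range of 4 uL/min to 22 uL/min. This estimate means a step of a 1.3-fold lower number from compound 2 to compound 4 (0.11 log units; within the scatter), which is expected to remain inside the scatter.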

Compound 4, intrinsic clearance in a liver preparation (reported as CLH), per the amount of preparation that the assay uses: 14 uL/min
Compound 4: the middle estimate sits 1.4-fold (0.15 log units) below what was measured; the measured number falls inside the stated range.
By their numbers in this assay, from the lowest: compounds 2, 4 and 1 (each within the scatter of the next). At a limit, below all of these: compound 3.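

In this assay fluoro in place of hydrogen on this aromatic carbon, ortho to the existing fluoro group and meta to the 1H-pyrazol-1-yl group, gives a 1.1-fold higher number from compound 2 to compound 4 (0.03 log units; within the scatter). Within the data shown here, this is the only reading of this change, and at this position the added fluoro leaves clearance indistinguishable from that of the parent compound. The data shown give no cause for this result.

One position and one small substituent say nothing about how a larger group, such as chloro, methoxy or nitrile, would behave on the same carbon. Also open, from the compounds shown here alone, is whether fluoro in place of hydrogen on the other aromatic carbons of this ring would leave the number as unchanged as it does here.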